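The source may hold more compounds than are shown below. What is called first, only, known or untested is meant among the compounds shown, and "the series" means these compounds.

Compound 1 `Cc1ccc(NC(=O)Nc2cc(C)nc3ccccc23)cc1` — an ADME assay on BJ cells (Homo sapiens) for cytotoxicity, with a stated time of 72 h; on this read-out higher numbers stand for an effect only at larger amounts of compound and lower numbers for an effect already at smaller amounts: > 25000 nM
Compound 2 `Cc1cc(NC(=O)Nc2ccc(N)cc2)c2ccccc2n1` — this assay : > 25000 nM

In this assay compound 1 gives > 25000 nM, which is a limit of the assay and not a number. Compound 2 likewise gives > 25000 nM in this assay, again a limit rather than a number. Among the compounds with values here, compound 2 therefore stands at the limit, where the only other value shown also sits; (the limit of > 25000 nM in this assay, at which 2 of the 2 values shown sit). The step that the two limits leave unreadable from compound 1 to compound 2 is unreadable, both of its ends being limits.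

Compound 3 `CC(=O)c1ccc(NC(=O)Nc2cc(C)nc3ccccc23)cc1` is to be measured in this assay.

acetyl in place of amino on an aromatic carbon

Within the data shown here, the only measured step, a step that the two limits leave unreadable from compound 1 to compound 2, bears on this change but gives no size, so no shift beyond the scatter can be read from it in either direction. Compound 3 is expected to sit at or near the same limit, with the step that the limit leaves unreadable from compound 2 to compound 3 expected to be small. The estimate for compound 3 is 30000 nM, with a range of 10000 nM to 100000 nM.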

Compound 3, half-maximal effective concentration: 22000 nM
Compound 3: the middle estimate sits 1.4-fold (0.13 log units) above what was measured; the measured number falls inside the stated range.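

In this assay, within the data shown here, compound 3 gives 22000 nM, the first value that is a number and not a limit, with acetyl on the aromatic carbon para to a large group. The change reads as an at least 1.1-fold lower number from compound 2 to compound 3 (0.05 log units; that floor lies within the scatter) and as an at least 1.1-fold lower number from compound 1 to compound 3 (0.05 log units; that floor lies within the scatter); both are only floors and lie within the scatter, so acetyl at this position is not shown to differ from amino or methyl, though the true steps could be larger. The values for compound 1 and compound 2 remain limits of the assay, not numbers: the limit of > 25000 nM in this assay, at which 2 of the 3 values shown sit.

Still open, from the compounds shown here alone, is whether a carboxylic acid, a longer chain or a dimethylamino group at this position gives a step clearly beyond the scatter. Also open, going by these compounds, is how far a change on the shared core would shift this read-out.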